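The source may report more compounds than this note shows. Statements on the series, on what has been measured and on what is new or still open speak of the compounds shown alone.

Measured compounds:
compound 1 `CC[C@H]1O[C@H](COCc2ccccc2)[C@@H](OCc2ccccc2)[C@H](OCc2ccccc2)[C@H]1O`: "not active" (no number reported)
compound 2 `C=CC[C@@H]1O[C@H](COCc2ccccc2)[C@@H](OCc2ccccc2)[C@H](OCc2ccccc2)C1=O`: 31800 nM
compound 3 `C=C[C@H]1O[C@H](COCc2ccccc2)[C@@H](OCc2ccccc2)[C@H](OCc2ccccc2)[C@H]1OC(C)=O`: "not active" (no number reported)

In a functional assay on HL-60 cells (Homo sapiens) for antiproliferative activity, read by MTT assay (a lower number here means a stronger inhibitor, a higher number a weaker inhibitor), compound 1 gives "not active" (no number reported), so no single number stands for it; compound 3 likewise gives "not active" (no number reported). Only compound 2 gives a number, 31800 nM. Compound 4 `O[C@H]1CO[C@H](COCc2ccccc2)[C@@H](OCc2ccccc2)[C@@H]1OCc1ccccc1` has not been measured yet. It differs from compound 1 by hydrogen in place of ethyl on a saturated ring carbon. Going by the values given here, no measured pair shows a change of this kind, so the size of the step in this assay cannot be read from the data; the expectation is a small step, in no clear direction, not beyond the usual scatter. Because compound 1 gives "not active" (no number reported) in this assay, compound 4 is expected to remain weak, estimated at about 60000 nM, within 20000 nM to 200000 nM, with a fair chance that again no single number is reported for it.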

Compound 4, half-maximal inhibitory concentration: "not active" (no number reported)
Compound 4 has no reported number here, so the estimate cannot be set against anything.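

In this assay compound 1 gives "not active" (no number reported) and compound 4 gives "not active" (no number reported) as well. Neither has a number, so no step can be read between them. As far as these compounds go, the effect of hydrogen in place of ethyl stays open, and nothing measured here bears on this result.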